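The compounds below may be only part of what the source reports. "The series", "measured", "known", "first", "only" and "open" are said of these compounds alone.

Measured in an ADME assay on MT4 cells (Homo sapiens) for cytotoxicity, read by MTT assay, with a stated time of 5 days; a higher number here means that more compound is tolerated, a lower number that less compound is tolerated:
- Compound 1 `COc1cc2nc([S+]([O-])CC(=O)Nc3cccc([N+](=O)[O-])c3)nc(Nc3c(Cl)cc(/C=C/C#N)cc3Cl)c2cc1OC`: >= 83200 nM (a limit)
- Compound 2 `COc1cc2nc([S+]([O-])CC(=O)Nc3ccccc3F)nc(Nc3c(Cl)cc(/C=C/C#N)cc3Cl)c2cc1OC`: > 208000 nM (a limit)

Neither compound has a number in this assay. Compound 2 stands at the limit of > 208000 nM in this assay, at which 1 of the 2 values shown sits. Compound 1 stands at the limit of >= 83200 nM in this assay, at which 1 of the 2 values shown sits. Compound 3 `COc1cc2nc([S+]([O-])CC(=O)Nc3ccc(C(F)(F)F)cc3)nc(Nc3c(Cl)cc(/C=C/C#N)cc3Cl)c2cc1OC` keeps the shared core and changes one group, with 4-(trifluoromethyl)phenyl in place of 2-fluorophenyl on an amide-type nitrogen.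

Within the data shown here, only one measured step bears on this change, and it alters the same amide-type nitrogen substituent. It is a step that the two limits leave unreadable from compound 1 to compound 2, so it offers no size to carry over. The expectation therefore rests on compound 2 and compound 1 both being reported only as limits, which gives no sign of a direction for the new group. No step beyond the usual scatter is expected, and the estimated step is an at least 1.6-fold lower number from compound 2 to compound 3 (0.20 log units; that floor lies within the scatter). A further limit rather than a number is the likeliest report. For compound 3 the estimated value is 130000 nM, with an expected range from 40000 nM to 300000 nM.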

Compound 3, half-maximal cytotoxic concentration: 22000 nM
Compound 3: the middle estimate sits 5.9-fold (0.77 log units) above what was measured, and the stated range ends above it.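

In this assay, the substituent on the amide-type nitrogen now proves able to move the read-out, and compound 3 is the only one of the three to carry a number: 4-(trifluoromethyl)phenyl in place of 2-fluorophenyl gives an at least 9.4-fold lower number from compound 2 to compound 3 (0.97 log units; beyond the scatter), and in place of 3-nitrophenyl it gives an at least 3.7-fold lower number from compound 1 to compound 3 (0.57 log units; beyond the scatter), both sizes being floors only. Compound 2 remains a limit, which is why the first step has no upper end: the limit of > 208000 nM in this assay, at which 1 of the 3 values shown sits.
Compound 1 also remains a limit, which is why the second step has no upper end: the limit of >= 83200 nM in this assay, at which 1 of the 3 values shown sits.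

The step between compound 1 and compound 2 cannot be read, and these compounds leave open whether the lower number belongs to the trifluoromethyl group itself or to the whole 4-(trifluoromethyl)phenyl arrangement, since the three aryl groups differ in more than one feature. They also leave open how a plain phenyl, or a phenyl ring carrying an amine or a carboxylic acid, would stand on the same nitrogen in this assay.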